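This account rests on a few compounds, and the source may have more. Where it says the series, first, only, none or still open, it means among the compounds named here.

Measured so far:
compound 1 `CNC(=O)c1cc(Oc2ccc(C3=NNC(c4ccc(C#N)cc4)C3)cc2)ccn1`: 9910 nM
compound 2 `CNC(=O)c1cc(Oc2ccc(C3=NNC(c4ccc(OC)cc4)C3)cc2)ccn1`: 7740 nM
compound 3 `CNC(=O)c1cc(Oc2ccc(C3=NNC(c4ccccc4)C3)cc2)ccn1`: 4520 nM

In a functional assay on PC-3 cells (Homo sapiens) for cytotoxicity, read by MTT assay, with a stated time of 72 h (on this read-out higher numbers stand for weaker inhibition and lower numbers for stronger inhibition), compound 1 gives the highest number of the three: a 1.3-fold lower number from compound 1 to compound 2 (0.11 log units; within the scatter), a 2.2-fold lower number from compound 1 to compound 3 (0.34 log units; beyond the scatter), while a 1.7-fold lower number from compound 2 to compound 3 (0.23 log units; within the scatter). Compound 4 `CNC(=O)c1cc(Oc2ccc(C3=NNC(c4ccc(F)cc4)C3)cc2)ccn1` differs from compound 1 by fluoro in place of cyano on an aromatic carbon. Going by the values given here, the steps that bear on this exchange both remove the cyano from the same aromatic carbon: the change to methoxy lies within the scatter, the change to hydrogen is modest. Replacing the cyano with fluoro is therefore expected to lower the number at most modestly, quite possibly within the scatter, the expected step being a 1.7-fold lower number from compound 1 to compound 4 (0.22 log units; within the scatter). Compound 4 is estimated to give about 6000 nM, within a range of 3000 nM to 12000 nM.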

Compound 4, half-maximal inhibitory concentration: 6770 nM
Beside the measured number, compound 4's estimate is 1.1-fold (0.05 log units) below it, within the range that was stated.
By their numbers in this assay, from the lowest: compounds 3, 4, 2 and 1 (each within the scatter of the next, the first and the last beyond it).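

In this assay, fluoro on this aromatic carbon stands within the scatter of all three other groups (a 1.5-fold lower number from compound 1 to compound 4 (0.17 log units; within the scatter); a 1.5-fold higher number from compound 3 to compound 4 (0.18 log units; within the scatter); a 1.1-fold lower number from compound 2 to compound 4 (0.06 log units; within the scatter)). Going by these compounds alone, compound 4 therefore separates from none of the others, and the exchange of cyano for hydrogen remains the only step here beyond the scatter. No evidence on the reason for these numbers is at hand.
As far as these compounds go, whether an amine or a carboxylic acid at this place would move the number further remains open, as does the effect of any of these groups on another carbon of the ring.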